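Pyridin-2-yl for 5-ethylfuran-2-yl on a shared core

The source may report more compounds than this note shows. Statements on the series, on what has been measured and on what is new or still open speak of the compounds shown alone.

Of the compounds shown here, three have been measured in a functional assay on CHO-K1 cells for antagonist activity at adenosine receptor A1 (Homo sapiens), read by a beta-galactosidase reporter and cAMP accumulation, with stated times of 15 min and 6 h; a lower number here means a stronger inhibitor, a higher number a weaker inhibitor. Compound 1 `Cc1ccc(-c2nc(N)c3cc(-c4ccccc4)sc3n2)o1` gives 520 nM. Compound 2 `CCc1ccc(-c2nc(N)c3cc(Cc4ccccc4)sc3n2)o1` gives 223 nM, the second highest of the three numbers; its nearest neighbour is compound 1, and compound 3 `Cc1csc(-c2nc(N)c3cc(Cc4ccccc4F)sc3n2)n1`, with 28.6 nM, lies furthest from it. The compound that is still unmeasured is compound 4 `Nc1nc(-c2ccccn2)nc2sc(Cc3ccccc3)cc12`, which differs from compound 2 in one place: pyridin-2-yl in place of 5-ethylfuran-2-yl on an aromatic carbon. Among the measured compounds shown here, no pair of measured compounds differs in exactly this way, so the size of this particular step is unknown. Compounds 1 and 3 show that the heteroaromatic ring in this place is one of several features that shift the number, but neither of them shares the rest of compound 2 unchanged. The expectation is therefore a modest step, a 1.2-fold lower number from compound 2 to compound 4 (0.09 log units; within the scatter), with no clear direction beyond the scatter. Compound 4 is expected to give about 180 nM in this assay, within a range from 50 nM to 600 nM.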

Compound 4, inhibition constant: 3710 nM
Compound 4: middle estimate off by 21-fold (1.31 log units), on the low side; measured number above the stated range.
By their numbers in this assay, from the lowest: compound 3; then compound 2; then compound 1; then compound 4.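

In this assay, putting pyridin-2-yl in place of 5-ethylfuran-2-yl on the shared core gives a 17-fold higher number from compound 2 to compound 4 (1.22 log units; beyond the scatter) and shows that this position is far from indifferent to the aromatic ring it carries. The two groups match in hydrogen-bond donors, hydrogen-bond acceptors and net charge, so a large step can occur here without any change in those counts. Nothing measured here says what lies behind the step.

The change replaces the five-membered ring with a six-membered one and removes the ethyl group at the same time, and the compounds shown cannot separate these two changes. Going by these compounds, whether an unsubstituted furan-2-yl, or a pyridin-2-yl carrying an ethyl group, would give a number closer to that of compound 2 or compound 4 remains open.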